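Swapping the pyrazole for a substituted phenyl ring

A few compounds are considered here, and "the series" means these few. Any claim that something is new, unique, unknown or untested is made for them only; others in the source may bear on it.

Measured so far:
compound 1 `Cc1nn(-c2nc(-c3ccc(Cl)c(Cl)c3)c(SC(C)C)s2)c(C(=O)O)c1-c1cnn(C)c1` — 6800 nM
compound 2 `Cc1nn(-c2nc(-c3ccc(Cl)c(Cl)c3)c(SC(C)C)s2)c(C(=O)O)c1-c1cc(C(F)(F)F)cc(C(F)(F)F)c1` — 1800 nM

In a functional assay on BJAB cells (Homo sapiens) for antiproliferative activity, with a stated time of 4 days (on this read-out higher numbers stand for an effect only at larger amounts of compound and lower numbers for an effect already at smaller amounts), compound 1 gives 6800 nM, the highest of the two numbers shown, while compound 2 gives 1800 nM, a gap that lies beyond the usual scatter. Compound 3 `COc1cc(C#N)cc(-c2c(C)nn(-c3nc(-c4ccc(Cl)c(Cl)c4)c(SC(C)C)s3)c2C(=O)O)c1` has not yet been measured in this assay. Compared with compound 1, it differs in one place: 3-cyano-5-methoxyphenyl in place of 1-methyl-1H-pyrazol-4-yl on an aromatic carbon. Like compound 2, compound 3 carries a six-membered aromatic ring of carbon only on the core, and on that ground a step toward lower numbers is expected. Among the compounds with values here, because compound 2 gives 1800 nM, a number below the one of compound 1, the step of a 2.4-fold lower number from compound 1 to compound 3 (0.39 log units; beyond the scatter) is expected to be modest but beyond the scatter. For compound 3 the estimate is 2800 nM, with a range from 1000 nM to 7500 nM.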

Compound 3, half-maximal effective concentration: 5200 nM
Beside the measured number, compound 3's estimate is 1.9-fold (0.27 log units) below it; low and high end bracket the measured number.
By their numbers in this assay, from the lowest: compound 2; then compounds 3 and 1 (each within the scatter of the next).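

Replacing 1-methyl-1H-pyrazol-4-yl with 3-cyano-5-methoxyphenyl, on the aromatic carbon next to the ring atom that bears a carboxy group, gives a 1.3-fold lower number from compound 1 to compound 3 (0.12 log units; within the scatter) in this assay. A six-membered aromatic ring of carbon only is therefore not enough at this position to move a compound away from compound 1, and among the compounds shown, the lower number of compound 2 at 1800 nM goes with trifluoromethyl groups on that ring rather than with the ring itself. Nothing at hand explains this result.

On these data alone, the separate contributions of the nitrile and the methoxy group remain open. So does the effect of an unsubstituted phenyl ring, or of a phenyl ring bearing a single trifluoromethyl group or an amine, at this position.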